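This account rests on a few compounds, and the source may have more. Where it says the series, first, only, none or still open, it means among the compounds named here.

Compound 1 `CCCc1ccc(-c2ccc3ncc(-c4noc(C)n4)cc3c2)cc1`: > 7400 nM
Compound 2 `Cc1ccc(-c2ccc3ncc(-c4noc(C)n4)cc3c2)cc1`: > 7400 nM

In a functional assay on RD cells (Homo sapiens) for inhibition, read by luminescence and ATP content, with a stated time of 72 h (a higher number here means that more compound is tolerated, a lower number that less compound is tolerated), compound 1 gives only a limit, > 7400 nM. Compound 2 likewise gives only a limit, > 7400 nM. The step from one to the other is a step that the two limits leave unreadable from compound 1 to compound 2, because both compounds sit at the limit of > 7400 nM in this assay, at which 2 of the 2 values shown sit. Compound 3 `Cc1nc(-c2cnc3ccc(-c4ccc(O)cc4)cc3c2)no1` differs from compound 2 by hydroxy in place of methyl on an aromatic carbon. Among the compounds with values here, no measured step covers a change of this kind, and the single measured step is unreadable, so nothing points to a step in this assay beyond the scatter. Compound 3 is therefore expected to give about 9000 nM in this assay, within 3000 nM to 30000 nM, most likely again as a limit. The expected step is a step that the limit leaves unreadable from compound 2 to compound 3.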

Compound 3, half-maximal cytotoxic concentration: > 2500 nM
Compound 3: a limit, no number; the forecaster's own chance of this, stated with the estimate: 75%; the middle value lies beyond the limit too.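

Compound 3 gives only a limit of > 2500 nM and its steps from compound 1 and from compound 2 cannot be read. In this assay the compounds shown leave open whether hydroxy in place of methyl changes how much compound is tolerated.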